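Bromo in Place of Fluoro on Compound 3

The source may hold more compounds than are shown below. What is called first, only, known or untested is meant among the compounds shown, and "the series" means these compounds.

Measured so far:
- compound 1 `C#CCSc1nc(NCCC(C)C)c2ccncc2n1` gives > 80000 nM
- compound 2 `C#CCSc1nc(Nc2ccccc2)c2ccncc2n1` gives 16200 nM
- compound 3 `C#CCSc1nc(Nc2ccc(F)cc2)c2ccncc2n1` gives 15800 nM

All three were tested in a functional assay on MGC-803 cells (Homo sapiens) for inhibition, read by MTT assay, with a stated time of 72 h; on this read-out higher numbers stand for weaker inhibition and lower numbers for stronger inhibition. The number shown for compound 1 is only a limit of the assay, not a measured value (the limit of > 80000 nM in this assay, at which 1 of the 3 values shown sits). Replacing isopentyl with phenyl gives an at least 4.9-fold lower number from compound 1 to compound 2 (0.69 log units; beyond the scatter), and replacing it with 4-fluorophenyl gives an at least 5.0-fold lower number from compound 1 to compound 3 (0.70 log units; beyond the scatter). Between the two phenyl compounds, putting fluoro in place of hydrogen gives a 1.0-fold lower number from compound 2 to compound 3 (0.01 log units; within the scatter), so compound 3 stands with the lowest of the two numbers, and compound 2 sits within the scatter of it.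

Compound 4 `C#CCSc1nc(Nc2ccc(Br)cc2)c2ccncc2n1` is not yet measured. It differs from compound 3 as follows: bromo in place of fluoro on an aromatic carbon. Among the measured compounds shown here, the only measured step that bears on this change is the swap of hydrogen for fluoro at the same place, which gave a 1.0-fold lower number from compound 2 to compound 3 (0.01 log units; within the scatter). Since one halogen there left the number unchanged, a larger halogen is expected to move it little, if at all. Compound 4 is therefore estimated to show a step of a 1.2-fold lower number from compound 3 to compound 4 (0.08 log units; within the scatter) in this assay, no larger than the scatter. Compound 4 is expected to give about 13000 nM, in a range from 5000 nM to 35000 nM.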

Compound 4, half-maximal inhibitory concentration: 26000 nM
Beside the measured number, compound 4's estimate is 2.0-fold (0.30 log units) below it, and the stated range covers the measured number.
By their numbers in this assay, from the lowest: compounds 3, 2 and 4 (each within the scatter of the next). At a limit, above all of these: compound 1.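

In this assay, compound 4 gives the position a second halogen to read, and a much larger one: the swap gives a 1.6-fold higher number from compound 3 to compound 4 (0.22 log units; within the scatter), and measured against the plain phenyl the step is a 1.6-fold higher number from compound 2 to compound 4 (0.21 log units; within the scatter). Both fluoro and bromo at this place, para to a large group, therefore leave the number within the scatter of the unsubstituted compound, so among these three compounds the size of the halogen shows no effect that can be told apart from repeat variation. The one change that stands out remains the group on the nitrogen, since 4-bromophenyl in place of isopentyl gives an at least 3.0-fold lower number from compound 1 to compound 4 (0.48 log units; beyond the scatter), and that step has no fixed size since the number for compound 1 is only a limit: the limit of > 80000 nM in this assay, at which 1 of the 4 values shown sits.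

As far as these compounds go, what a methoxy group, an amine or a carboxylic acid would do at this place stays open. Halogens are the only groups shown here. From the compounds shown here alone, how a group placed elsewhere on the phenyl ring, or a change to the shared core, would shift these numbers also stays open.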